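A few compounds are considered here, and "the series" means these few. Any claim that something is new, unique, unknown or untested is made for them only; others in the source may bear on it.

Values measured in a functional assay on LOX IMVI cells (Homo sapiens) for inhibition, read by sulforhodamine B assay, with a stated time of 48 h; on this read-out lower numbers stand for stronger inhibition of growth and higher numbers for weaker inhibition of growth:
- compound 1 `COc1cc2nc(-c3ccc(C(F)(F)F)cc3)cc(OCCCN3CCCC3)c2cc1OC`: 275 nM
- compound 2 `COc1cc2nc(-c3ccc(Cl)cc3)cc(OCCCN3CCC(O)CC3)c2cc1OC`: 589 nM

Of these two, compound 2 has the higher number, 589 nM, and so the weaker growth inhibition. Its gap to compound 1 lies beyond the usual scatter. The two compounds differ in more than one place, so that gap cannot be tied to any single change.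

Compound 3 `COc1cc2nc(-c3ccc(Cl)cc3)cc(OCCCN3CCCC3)c2cc1OC` follows from compound 2 by one change, pyrrolidin-1-yl in place of 4-hydroxypiperidin-1-yl on a saturated chain carbon, three bonds along the chain from an oxygen on an aromatic ring. Within the data shown here, no measured pair isolates this change, so any expectation is rough. Among the measured compounds shown here, the only measured compound with 3-(pyrrolidin-1-yl)propyl is compound 1, at 275 nM, which points to a modest move towards a lower number. The expected size is a 1.8-fold lower number from compound 2 to compound 3 (0.26 log units; within the scatter), close to the edge of the scatter. In this assay, the estimated value for compound 3 is 320 nM, with a range of 140 nM to 700 nM.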

Compound 3, concentration for total growth inhibition: 446 nM
Compound 3: middle estimate off by 1.4-fold (0.14 log units), on the low side; the measured number falls inside the stated range.
By their numbers in this assay, from the lowest: compounds 1, 3 and 2 (each within the scatter of the next, the first and the last beyond it).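

In this assay, pyrrolidin-1-yl in place of 4-hydroxypiperidin-1-yl on a saturated chain carbon, with the chloro group held fixed, gives a 1.3-fold lower number from compound 2 to compound 3 (0.12 log units; within the scatter) and so does not clearly separate the two amines. With the 3-(pyrrolidin-1-yl)propyl chain held fixed, chloro in place of trifluoromethyl on an aromatic carbon gives a 1.6-fold higher number from compound 1 to compound 3 (0.21 log units; within the scatter) and so, on its own, also stays short of a clear difference. No measurement shown here explains either step.

The amine change alters the ring size and removes the hydroxyl group at once, and a plain piperidin-1-yl group on the same chain would tell these two apart. Also open, as far as these compounds go, is how a longer chain or a methoxy group in place of chloro would read.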